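Sulfonyl hydrazone series: a bromo step from compound 3

A few compounds are considered here, and "the series" means these few. Any claim that something is new, unique, unknown or untested is made for them only; others in the source may bear on it.

Compound 1 `Cc1ccc([N+](=O)[O-])cc1S(=O)(=O)N(C)/N=C/c1ncc2ccccn12` in an assay on isolated protein for inhibition of phosphatidylinositol 4,5-bisphosphate 3-kinase catalytic subunit beta isoform (Homo sapiens) (on this read-out higher numbers stand for weaker inhibition and lower numbers for stronger inhibition), gives > 10000 nM.
Compound 2 `Cc1ccc([N+](=O)[O-])cc1S(=O)(=O)N(C)/N=C/c1onc2ccccc12` in this assay gives > 10000 nM.
Compound 3 `Cc1ccc([N+](=O)[O-])cc1S(=O)(=O)N(C)/N=C/c1cncc2ccccc12` in this assay gives > 10000 nM.

All three values are limits of this assay, not numbers. Compound 3 therefore stands at the limit, with no measured position inside the range of the assay, and the other two compounds sit at the same limit (the limit of > 10000 nM in this assay, at which 3 of the 3 values shown sit). Among the compounds with values here, no step between measured compounds can be sized from these data.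

Compound 4 `Cc1ccc([N+](=O)[O-])cc1S(=O)(=O)N(C)/N=C/c1cncc2c(Br)cccc12` differs from compound 3 by bromo in place of hydrogen on an aromatic carbon. Within the data shown here, nothing among the measured compounds shows any change in this assay, so for the step from compound 3 to compound 4 no shift beyond the scatter is expected a step that the limit leaves unreadable from compound 3 to compound 4. Compound 4 is estimated to fall around 15000 nM (range 5000 nM to 50000 nM), most likely reported again as a limit.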

Compound 4, half-maximal inhibitory concentration: > 10000 nM
Compound 4: no number, only a limit (the forecaster's own chance of this, stated with the estimate: 85%); the middle value does not contradict the limit.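

No size can be read for the bromo step between compound 3 and compound 4, as both values are limits: the limit of > 10000 nM in this assay, at which 4 of the 4 values shown sit.

The compounds shown leave open which change to the shared core, if any, would give a measured value inside the range of this assay.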